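Swapping acetyl for cyano on the sulfonyl-bearing alkene

A few compounds are considered here, and "the series" means these few. Any claim that something is new, unique, unknown or untested is made for them only; others in the source may bear on it.

Compound 1 `COc1ccc2[nH]c(-c3ccccc3)c(C=C(C#N)C#N)c2c1` and compound 2 `CC(=O)/C(=C\c1c(-c2ccccc2)[nH]c2ccccc12)S(=O)(=O)c1ccccc1` share a core and were both tested in a functional assay on A498 cells (Homo sapiens) for inhibition, read by sulforhodamine B assay, with a stated time of 48 h; a lower number here means a stronger inhibitor of growth, a higher number a weaker inhibitor of growth. In this assay compound 1 gives 2000 nM. Compound 2 gives 2000 nM, level with compound 1 within the scatter. Compound 3 `N#C/C(=C\c1c(-c2ccccc2)[nH]c2ccccc12)S(=O)(=O)c1ccccc1` differs from compound 2 by one change: cyano in place of acetyl on a double-bonded chain carbon bound to a double-bonded chain carbon and a sulfonyl sulfur. Because compound 1 with its cyano groups gives 2000 nM and compound 2 with acetyl gives 2000 nM, this step is expected to bring no change beyond the scatter, so no change at the digits printed from compound 2 to compound 3 (within the scatter) is the estimated step. Compound 3 is therefore estimated at 2000 nM, with a range from 700 nM to 6000 nM.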

Compound 3, concentration for 50% growth inhibition: 11000 nM
Compound 3: middle estimate off by 5.5-fold (0.74 log units), on the low side, outside the stated range (above it).
By their numbers in this assay, from the lowest: compounds 1 and 2 (each within the scatter of the next); then compound 3.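

At this position acetyl and cyano are not interchangeable: in this assay, cyano in place of acetyl gives a 5.5-fold higher number from compound 2 to compound 3 (0.74 log units; beyond the scatter). The rest of the molecule stays the same, so this single exchange on the double-bonded chain carbon is enough to weaken growth inhibition beyond the scatter. Nothing measured here explains why the number rises.

On these data alone, it remains open whether a carboxylic acid, an ethyl ester or a benzoyl group at this carbon would track with acetyl or with cyano. As far as these compounds go, whether the same swap has a similar effect on another core also remains open.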